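The source may report more compounds than this note shows. Statements on the series, on what has been measured and on what is new or still open speak of the compounds shown alone.

Of the compounds shown here, three that share one core have been measured in a functional assay on PC-3 cells (Homo sapiens) for inhibition; on this read-out lower numbers stand for stronger inhibition and higher numbers for weaker inhibition. Compound 1 `COc1cc2nc(N3CCN(S(=O)(=O)c4ccc(Cl)cc4)CC3)nc(N)c2cc1OC` gives 23000 nM in this assay. Compound 2 `COc1cc2nc(N3CCN(S(=O)(=O)c4ccc(C)cc4)CC3)nc(N)c2cc1OC` gives 30000 nM, and compound 3 `COc1cc2nc(N3CCN(S(=O)(=O)c4ccc(C(C)(C)C)cc4)CC3)nc(N)c2cc1OC` gives 4100 nM. Compound 3 stands lowest of the three, and both of its steps from the other two lie beyond the scatter: a 5.6-fold lower number from compound 1 to compound 3 (0.75 log units; beyond the scatter) and a 7.3-fold lower number from compound 2 to compound 3 (0.86 log units; beyond the scatter). Between the other two, a 1.3-fold higher number from compound 1 to compound 2 (0.12 log units; within the scatter), so compound 1 and compound 2 are not separated by this assay.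

Compound 4 `COc1cc2nc(N3CCN(S(=O)(=O)c4ccc(N)cc4N)CC3)nc(N)c2cc1OC` has not yet been measured. It differs from compound 3 in one place: 2,4-diaminophenyl in place of 4-(tert-butyl)phenyl on a sulfonyl sulfur. The two steps that bear on this change are the two that lead to compound 3, in which tert-butyl replaced chloro or methyl and each time brought a modest lowering of the number. Among the measured compounds shown here, compound 4 gives up the tert-butyl again, and no measured step shows what a 2,4-diaminophenyl does on the sulfonyl sulfur. The expectation is therefore a return toward the numbers of compound 1 and compound 2. A higher number is expected, a 6.1-fold higher number from compound 3 to compound 4 (0.79 log units; beyond the scatter), with wide uncertainty. Compound 4 is estimated at 25000 nM in this assay, within a range from 6000 nM to 100000 nM.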

Compound 4, half-maximal inhibitory concentration: 67000 nM
Compound 4: middle estimate off by 2.7-fold (0.43 log units), on the low side; the range from low to high includes it.
By their numbers in this assay, from the lowest: compound 3; then compounds 1 and 2 (each within the scatter of the next); then compound 4.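

In this assay the 2,4-diaminophenyl group does more than give up what the 4-(tert-butyl)phenyl group gained, for the number rises past the level of the 4-chlorophenyl and 4-methylphenyl compounds, with a 2.9-fold higher number from compound 1 to compound 4 (0.46 log units; beyond the scatter) and a 2.2-fold higher number from compound 2 to compound 4 (0.35 log units; beyond the scatter). The full swing among the groups on the sulfonyl sulfur is a 16-fold higher number from compound 3 to compound 4 (1.21 log units; beyond the scatter), the largest step in the set, so this position can move the read-out well in either direction from the level of the chloro and methyl compounds, and the change that brings in hydrogen-bond donors lands at the high end of the numbers. No evidence is at hand on what lies behind this rise.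

The compounds shown leave open whether both amino groups of the 2,4-diaminophenyl group take part in the rise, as a phenyl ring carrying a single amino group does not appear among them. Also open, going by these compounds, is whether the lowering seen with tert-butyl continues with other branched carbon groups, such as cyclohexyl or adamantyl, on the same aromatic carbon.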